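Same aryl swap on a second urea core

This account rests on a few compounds, and the source may have more. Where it says the series, first, only, none or still open, it means among the compounds named here.

Compound 1 `COc1ccc(Br)cc1Nc1cc(NC(=O)Nc2c(Cl)cccc2Cl)ncn1` carries a 5-bromo-2-methoxyphenyl group on a nitrogen on an aromatic ring, and in a functional assay on NCI-H520 cells (Homo sapiens) for inhibition, read by MTT assay, with a stated time of 48 h, tested at 10 uM (a higher number here means more inhibition at the concentration tested (going by the name of the read-out), a lower number less inhibition), compound 1 gives 45%. Compound 2 `COc1ccc(Nc2cc(NC(=O)Nc3c(Cl)cccc3Cl)ncn2)cc1C` differs from it in one place, (4-methoxy-3-methylphenyl in place of 5-bromo-2-methoxyphenyl on a nitrogen on an aromatic ring), and compound 2 gives 29.1%. Going by the values given here, the step of a number 15.9 percentage points lower from compound 1 to compound 2 (beyond the scatter) is the one piece of direct evidence on this exchange.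

Compound 3 `COc1cc(NC(=O)Nc2cc(Nc3cc(Br)ccc3OC)ncn2)cc(OC)c1` shares the same 5-bromo-2-methoxyphenyl group but sits on a different core; the two cores differ by 3,5-dimethoxyphenyl in place of 2,6-dichlorophenyl on an amide-type nitrogen. Compound 3 gives 43.5%, and the step of a number 1.5 percentage points lower from compound 1 to compound 3 (within the scatter) shows that the core change alone leaves the read-out essentially where it was.

Compound 4 `COc1cc(NC(=O)Nc2cc(Nc3ccc(OC)c(C)c3)ncn2)cc(OC)c1` has not yet been measured. It is related to compound 3 by 4-methoxy-3-methylphenyl in place of 5-bromo-2-methoxyphenyl on a nitrogen on an aromatic ring, which is the same change as that from compound 1 to compound 2, made at the same kind of place with the same neighbours. Since the two cores behave alike in compound 1 and compound 3, the step from compound 3 to compound 4 is expected to be of similar size to the earlier one, estimated as a number 15.5 percentage points lower from compound 3 to compound 4 (beyond the scatter), resting on the drop seen in a number 15.9 percentage points lower from compound 1 to compound 2 (beyond the scatter). Compound 4 is therefore expected to give about 28%, with a plausible range from 15% to 40%.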

Compound 4, a percentage reported as inhibition, at one concentration (the size of the read-out at that concentration, not a potency): 13.5%
The estimate for compound 4 lay 14.5 percentage points above the measured number; the measured number lies below the stated range.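

In this assay the exchange of 5-bromo-2-methoxyphenyl for 4-methoxy-3-methylphenyl on the aromatic-ring nitrogen kept its direction on the second core, giving a number 30 percentage points lower from compound 3 to compound 4 (beyond the scatter), but its size did not carry over: the same change on two cores in this assay, a number 15.9 percentage points lower (beyond the scatter) from compound 1 to compound 2 and a number 30 percentage points lower (beyond the scatter) from compound 3 to compound 4, 14.1 percentage points apart, beyond the scatter of two such steps

The other exchange in the set, 3,5-dimethoxyphenyl for 2,6-dichlorophenyl on the amide-type nitrogen, also depended on its surroundings, since with the 4-methoxy-3-methylphenyl group in place it gave a number 15.6 percentage points lower from compound 2 to compound 4 (beyond the scatter), whereas it had made no difference beyond the scatter with the 5-bromo-2-methoxyphenyl group: the same change on two cores in this assay, a number 1.5 percentage points lower (within the scatter) from compound 1 to compound 3 and a number 15.6 percentage points lower (beyond the scatter) from compound 2 to compound 4, 14.1 percentage points apart, beyond the scatter of two such steps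

Across these four compounds the two exchanges therefore do not add independently, so a step measured on one core is a guide to direction here but not to size, while the data do not show why the steps differ or whether the same holds for any other pair of groups.

The compounds shown leave open which part of the exchange on the aromatic-ring nitrogen, the bromine, the methyl or the place of the methoxy, accounts for the steps. They also leave open how a 5-chloro-2-methoxyphenyl group, or a morpholine or carboxylic acid on either aryl ring, would behave on these two cores.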